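Replacing the pendant aryl group with pyridin-3-yl

The compounds below may be only part of what the source reports. "The series", "measured", "known", "first", "only" and "open" are said of these compounds alone.

Three analogues of a shared core differ only in the aryl group on an aromatic carbon of the five-membered aromatic ring with 2 nitrogen. In a functional assay on BJAB cells (Homo sapiens) for antiproliferative activity, with a stated time of 4 days (on this read-out lower numbers stand for an effect already at smaller amounts and higher numbers for an effect only at larger amounts of compound), compound 1 `COc1ccc(-c2c(C)nn(-c3nc(-c4ccc(Cl)c(Cl)c4)c(SC(C)C)s3)c2C(=O)O)cc1` gives 2100 nM and compound 2 `Cc1cc(C)cc(-c2c(C)nn(-c3nc(-c4ccc(Cl)c(Cl)c4)c(SC(C)C)s3)c2C(=O)O)c1` gives 2700 nM; the step of a 1.3-fold higher number from compound 1 to compound 2 (0.11 log units; within the scatter) is within the scatter. Compound 3 `COc1cc(Cl)cc(-c2c(C)nn(-c3nc(-c4ccc(Cl)c(Cl)c4)c(SC(C)C)s3)c2C(=O)O)c1` gives 760 nM and stands lowest of the three numbers, with a 2.8-fold lower number from compound 1 to compound 3 (0.44 log units; beyond the scatter) and a 3.6-fold lower number from compound 2 to compound 3 (0.55 log units; beyond the scatter) both modest but beyond the scatter.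

Compound 4 `Cc1nn(-c2nc(-c3ccc(Cl)c(Cl)c3)c(SC(C)C)s2)c(C(=O)O)c1-c1cccnc1` carries the change (pyridin-3-yl in place of 3-chloro-5-methoxyphenyl on an aromatic carbon). Among the compounds with values here, no measured step exchanges a carbon-only ring for one with a hetero atom, so none bears on it directly; the two steps into compound 3 show only that the aryl group shifts this assay by a modest amount. With the chlorine and the methoxy group of compound 3 both gone, a return toward the level of compound 1 is expected rather than a further drop, so the expected step is a 2.6-fold higher number from compound 3 to compound 4 (0.42 log units; beyond the scatter). Compound 4 is therefore estimated at 2000 nM, with a range from 700 nM to 6000 nM.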

Compound 4, half-maximal effective concentration: 12000 nM
Estimate against measurement, compound 4: 6.0-fold (0.78 log units) below; the measured number lies above the stated range.
By their numbers in this assay, from the lowest: compound 3; then compounds 1 and 2 (each within the scatter of the next); then compound 4.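

Among the groups shown at this aromatic carbon of the five-membered aromatic ring with 2 nitrogen, the carbon-only aryl groups stay within modest steps of one another in this assay, whereas pyridin-3-yl opens a large gap with a 16-fold higher number from compound 3 to compound 4 (1.20 log units; beyond the scatter). The new group also stands beyond the scatter from the two less favourable carbon-only aryl groups, with a 4.4-fold higher number from compound 2 to compound 4 (0.65 log units; beyond the scatter) and a 5.7-fold higher number from compound 1 to compound 4 (0.76 log units; beyond the scatter), so compound 4 has the highest number of the four and the position proves more sensitive than the first three compounds showed. Nothing at hand accounts for this rise.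

Compound 4 differs from each of the other compounds both in its ring nitrogen and in having no substituent on the pendant ring, so these two changes cannot be separated here. From the compounds shown here alone, a plain phenyl group and a pyridine ring carrying chlorine or methoxy would each divide that change, and it remains open whether either would stay near compound 3 at 760 nM or move toward compound 4 at 12000 nM.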